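The source may report more compounds than this note shows. Statements on the series, on what has been measured and on what is new or still open speak of the compounds shown alone.

Measured so far:
Compound 1 `OCc1cc2ccccc2nc1-c1ccccc1O`; in a functional assay on IMR-32 cells (Homo sapiens) for cytotoxicity, read by MTT assay, with a stated time of 24 h (a lower number here means a stronger inhibitor, a higher number a weaker inhibitor), compound 1 gives > 100000 nM, which is a limit of the assay and not a number.
Compound 2 `OCc1cc2cc(Cl)ccc2nc1-c1ccccc1O`; in this assay compound 2 gives 65000 nM.

Compound 1 stands at a limit, namely (the limit of > 100000 nM in this assay, at which 1 of the 2 values shown sits), so no number is known for it in this assay. For the measured compounds named here, the only measured step, an at least 1.5-fold lower number from compound 1 to compound 2 (0.18 log units; that floor lies within the scatter), concerns chloro in place of hydrogen on an aromatic carbon and is too small to count as a change.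

Compound 3 `[N-]=[N+]=NCc1cc2ccccc2nc1-c1ccccc1O` is the compound still to be measured. It differs from compound 1 by azido in place of hydroxy on a saturated chain carbon bound to an aromatic carbon. Among the measured steps none touches the hydroxymethyl group, so none bears on this change; the only step known is of a different kind and sits within the scatter. For that reason no step beyond the scatter in either direction is expected in this assay, and the most likely outcome is that compound 3 again sits at the limit.

Compound 3 is therefore estimated at 100000 nM, with a range from 30000 nM to 300000 nM. The expected step, a number no higher from compound 1 to compound 3 (the limit leaves the size open), is meant as no change beyond the scatter.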

Compound 3, half-maximal inhibitory concentration: 24000 nM
Beside the measured number, compound 3's estimate is 4.2-fold (0.62 log units) above it, outside the stated range (below it).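

In this assay, the change from hydroxymethyl to azidomethyl gives an at least 4.1-fold lower number from compound 1 to compound 3 (0.61 log units; beyond the scatter), so the group on this saturated chain carbon can move the number by more than the usual scatter. For the compounds shown here, the only earlier step, an at least 1.5-fold lower number from compound 1 to compound 2 (0.18 log units; that floor lies within the scatter), concerned a different place on the core and could not show this. Still, the true size of the new step remains unknown because compound 1 stands at a limit rather than at a number, which leaves only a floor for the step: the limit of > 100000 nM in this assay, at which 1 of the 3 values shown sits.

The swap also changes several things at once, as hydroxy leaves with its hydrogen-bond donor and azido enters with none, and a single pair of compounds cannot separate the loss of hydroxy from the arrival of azido. From the compounds shown here alone, what an amine, a carboxylic acid or a longer chain would give on this same carbon remains open, as does whether azido would give a step of similar size on the chloro-bearing core of compound 2.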